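The source may hold more compounds than are shown below. What is called first, only, known or untested is meant among the compounds shown, and "the series" means these compounds.

Compound 3 `Nc1nnc(Cc2ccc(Cl)cc2Oc2ccccc2F)o1` gives 154% in a functional assay on the whole organism (strain NMRI) with Mus musculus as the target, with a stated time of 60 min, at a dose of 20 mg/kg by the intraperitoneal route (a lower number here means a weaker effect, a higher number a stronger effect of the compound at the dose given), the second highest of the three numbers: compound 1 `CCCSc1nnc(Cc2ccc(Cl)cc2Oc2ccccc2F)[nH]1` gives 133% and compound 2 `Fc1ccccc1Oc1cc(Cl)ccc1Cc1nnc(SCc2ccccc2)[nH]1` gives 179%. Compound 4 `CCOc1nnc(Cc2ccc(Cl)cc2Oc2ccccc2F)[nH]1` differs from compound 3 by a group of 8 heavy atoms (4 carbon, 3 nitrogen, 1 oxygen; one five-membered aromatic ring with 3 hetero atoms) in place of a group of 6 heavy atoms (2 carbon, 3 nitrogen, 1 oxygen; one five-membered aromatic ring with 3 hetero atoms), on a saturated chain carbon bound to an aromatic carbon. Going by the values given here, the only measured step, a number 46 percentage points higher from compound 1 to compound 2 (beyond the scatter), alters the group on the sulfur and leaves the exchanged ring untouched, so it does not bear directly on the step to compound 4. Compound 4 shares its ring with compound 1, which gives 133%, a lower number than compound 3, so a downward step to compound 4 of about a number 14 percentage points lower from compound 3 to compound 4 (beyond the scatter) is expected. Compound 4 is estimated at 140%, within a range from 100% to 180%.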

Compound 4, a percentage reported as activity, at one dose (the size of the read-out at that dose, not a potency): 138%
Compound 4: the middle estimate sits 2 percentage points above what was measured; the measured number falls inside the stated range.
By their numbers in this assay, from the lowest: compounds 1 and 4 (each within the scatter of the next); then compound 3; then compound 2.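

In this assay, ethoxy and propylsulfanyl on the aromatic carbon cannot be told apart, with a number 5 percentage points higher from compound 1 to compound 4 (within the scatter). Ethoxy in place of benzylsulfanyl gives a number 41 percentage points lower from compound 2 to compound 4 (beyond the scatter), and the group of 8 heavy atoms in place of 5-amino-1,3,4-oxadiazol-2-yl, on the saturated chain carbon, gives a number 16 percentage points lower from compound 3 to compound 4 (beyond the scatter), so benzylsulfanyl stands apart from the two short chains. No measurement here explains the size of these steps. On these data alone, whether benzyloxy would match benzylsulfanyl remains open, as does what a dimethylamino group or a longer chain such as butoxy would give on this aromatic carbon.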